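This account rests on a few compounds, and the source may have more. Where it says the series, first, only, none or still open, it means among the compounds named here.

Compounds measured so far:
compound 1 `CNS(=O)(=O)c1ccc(NC(=O)NCc2ccncc2)cc1`: 3230 nM
compound 2 `CCOC(=O)c1ccc(N/C(=N\C#N)NCc2ccncc2)cc1`: 41400 nM

In an assay on isolated protein for activation of Nicotinamide phosphoribosyltransferase (Homo sapiens) (a higher number here means that more compound is needed for the effect, a lower number that less compound is needed), compound 1 gives 3230 nM. Compound 2 gives 41400 nM in this assay, a higher number than compound 1 by a margin that lies beyond the usual scatter, so compound 1 stands as the lower of the two numbers. The two differ in several places at once, so nothing can be read from that gap about any single change.

Compound 3 `O=C(NCc1ccncc1)Nc1ccc(S(=O)(=O)Nc2ccccc2)cc1` is not yet measured. It differs from compound 1 in one place: phenyl in place of methyl on a sulfonamide nitrogen. For the measured compounds named here, no measured pair here tracks this change, so the expectation rests on compound 1 alone. The step from compound 1 to compound 3 is expected to be a 1.6-fold lower number from compound 1 to compound 3 (0.21 log units; within the scatter), a small movement that may not exceed the scatter. For compound 3 the estimate in this assay is 2000 nM, with a range from 500 nM to 8000 nM.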

Compound 3, half-maximal effective concentration: 410 nM
The estimate for compound 3 lay 4.9-fold (0.69 log units) above the measured number; the whole stated range lies above it.
By their numbers in this assay, from the lowest: compound 3; then compound 1; then compound 2.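

In this assay, for the compounds shown here, phenyl in place of methyl on a sulfonamide nitrogen gives a 7.9-fold lower number from compound 1 to compound 3 (0.90 log units; beyond the scatter) and so supplies the first reading of a single change, which the gap between compound 1 and compound 2 could not give. It shows that the group on this nitrogen affects the number beyond the scatter, and that a six-membered aromatic ring of carbon only is accepted there with less compound needed for the effect. Nothing available here bears on why the number moved.

As far as these compounds go, whether this gain needs an aromatic ring or comes with any larger group stays open, and a cyclohexyl, a benzyl or an ethyl on the same nitrogen would bear on that. Also open, from the compounds shown here alone, is whether a phenyl carrying a methoxy or a carboxylic acid would move the number further.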